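This account rests on a few compounds, and the source may have more. Where it says the series, first, only, none or still open, it means among the compounds named here.

Compound 3 `CC(=O)Nc1ccc(-c2nc3ccccc3[nH]2)cc1` was tested in an ADME assay on MDBK cells (Bos taurus) for cytotoxicity, read by MTT assay, with a stated time of 96 h; a lower number here means that less compound is tolerated, a higher number that more compound is tolerated. In this assay compound 3 returns > 100000 nM, which is a limit of the assay rather than a measured number. Compound 2 `COc1ccc(-c2nc3cc(C(F)(F)F)ccc3[nH]2)cc1` also sits at a limit in this assay, > 100000 nM. Compound 1 `CC(=O)Nc1ccc(-c2nc3cc(C(F)(F)F)ccc3n2C)cc1` is the only one of the three with a number in this assay, 46000 nM. Compound 3 therefore stands, together with compound 2, at the limit of > 100000 nM in this assay, at which 2 of the 3 values shown sit, while compound 1 gives a number close to that point.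

Compound 4 `CC(=O)Nc1ccc(-c2nc3cc(C(F)(F)F)ccc3[nH]2)cc1` has not yet been measured in this assay. It differs from compound 3 by trifluoromethyl in place of hydrogen on an aromatic carbon. Among the compounds with values here, no measured pair shows this change on its own. Compound 1, which carries trifluoromethyl, gives 46000 nM, so the step in this assay is expected to be small, or none beyond the usual scatter, in either direction. Compound 4 is estimated to give 90000 nM, with a range from 40000 nM to 200000 nM, and is quite likely to return only a limit again. The expected step is an at least 1.1-fold lower number from compound 3 to compound 4 (0.04 log units; that floor lies within the scatter).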

Compound 4, half-maximal cytotoxic concentration: 50000 nM
The estimate for compound 4 lay 1.8-fold (0.26 log units) above the measured number, within the range that was stated.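

Trifluoromethyl in place of hydrogen on an aromatic carbon can now be read on its own in this assay, as an at least 2.0-fold lower number from compound 3 to compound 4 (0.30 log units; that floor lies within the scatter), and acetamido in place of methoxy on an aromatic carbon can be read as an at least 2.0-fold lower number from compound 2 to compound 4 (0.30 log units; that floor lies within the scatter). As far as these compounds go, both steps start from a limit, so their true size is unknown and their floors lie within the scatter, and the limit in question is this one: the limit of > 100000 nM in this assay, at which 2 of the 4 values shown sit. Hydrogen in place of methyl on an aromatic nitrogen gives a 1.1-fold higher number from compound 1 to compound 4 (0.04 log units; within the scatter), so this change shows nothing beyond the scatter.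

The compounds shown leave open how large the two steps that start from a limit really are. They also leave open what a nitrile or an amine on that aromatic carbon would give in this assay.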